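Trifluoromethyl for Methoxy on the Hydrazone Aryl Ring

The source may hold more compounds than are shown below. What is called first, only, known or untested is meant among the compounds shown, and "the series" means these compounds.

Compound 1 `COc1ccc(/C=N/NC(=O)Nc2ccc(Oc3ccnc4cc(OCCCN5CCCCC5)c(OC)cc34)c(F)c2)cc1` gives 590 nM in a functional assay on HT-29 cells (Homo sapiens) for cytotoxicity, read by MTT assay, with a stated time of 72 h; a lower number here means a stronger inhibitor, a higher number a weaker inhibitor. Compound 2 `COc1ccc(/C=N/NC(=O)Nc2ccc(Oc3ccnc4cc(OCCCN5CCC(C)CC5)c(OC)cc34)c(F)c2)cc1` gives 610 nM in this assay, and the step of a 1.0-fold higher number from compound 1 to compound 2 (0.01 log units; within the scatter) separates them, so on these two numbers compound 2 sits within the scatter of compound 1. Compound 3 `COc1cc2c(Oc3ccc(NC(=O)N/N=C/c4ccc(C(F)(F)F)cc4)cc3F)ccnc2cc1OCCCN1CCC(C)CC1` differs from compound 2 by trifluoromethyl in place of methoxy on an aromatic carbon. Among the measured compounds shown here, no measured step touches this aromatic position; the only step known concerns a saturated ring carbon. Without a guide, compound 3 is expected to stay near compound 2, the step of a 1.1-fold higher number from compound 2 to compound 3 (0.03 log units; within the scatter) estimated to fall within the scatter. Compound 3 is therefore estimated at 650 nM, between 250 nM and 1700 nM.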

Compound 3, half-maximal inhibitory concentration: 740 nM
Compound 3: middle estimate off by 1.1-fold (0.06 log units), on the low side; low and high end bracket the measured number.
By their numbers in this assay, from the lowest: compounds 1, 2 and 3 (each within the scatter of the next).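

Compound 3 carries the first change shown on an aromatic carbon, and replacing methoxy with trifluoromethyl there gives a 1.2-fold higher number from compound 2 to compound 3 (0.08 log units; within the scatter) in this assay. On these numbers, the 4-methoxyphenyl and 4-(trifluoromethyl)phenyl versions cannot be told apart in this assay, although the two groups differ in heavy atoms and hydrogen-bond acceptors. No measurement offered here bears on why.

From the compounds shown here alone, whether an amine or a carboxylic acid on this same aromatic carbon would stay within the scatter remains open. The same question applies to a longer chain such as ethoxy.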